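Cyclopentylamino in place of 2,2,2-trifluoroethoxy: a cytotoxicity outlook

The compounds below may be only part of what the source reports. "The series", "measured", "known", "first", "only" and "open" are said of these compounds alone.

Compound 3 `Nc1nc(OCC(F)(F)F)c2ncn(/C=C3/CC3(CO)CO)c2n1` has been tested in an ADME assay on CCRF-HSB-2 cells (Homo sapiens) for cytotoxicity, with a stated time of 7 days; on this read-out lower numbers stand for higher toxicity in this test and higher numbers for lower toxicity in this test. In this assay compound 3 gives > 20000 nM, which is a limit of the assay rather than a number. Compound 1 `CCCCCOc1nc(N)nc2c1ncn2/C=C1/CC1(CO)CO` in this assay gives > 20000 nM, again a limit. Compound 2 `CCCCNc1nc(N)nc2c1ncn2/C=C1/CC1(CO)CO` in this assay gives > 20000 nM, also a limit. Compound 3 thus stands where every value shown sits, namely at the limit of > 20000 nM in this assay, at which 3 of the 3 values shown sit, so nothing separates the three measured compounds on this read-out.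

Compound 4 `Nc1nc(NC2CCCC2)c2ncn(/C=C3/CC3(CO)CO)c2n1` has not been measured. It differs from compound 3 in one place: cyclopentylamino in place of 2,2,2-trifluoroethoxy on an aromatic carbon.

The measured steps that bear on this exchange are a step that the two limits leave unreadable from compound 2 to compound 3, a step that the two limits leave unreadable from compound 1 to compound 2 and a step that the two limits leave unreadable from compound 1 to compound 3. None of them has a readable size, as every end point is a limit, so they give no direction and no magnitude beyond the scatter to expect for the new exchange on the same aromatic carbon.

Compound 4 is therefore expected to sit again at the limit, with an estimate of 30000 nM in this assay, ranging from 12000 nM to 100000 nM. The expected step from compound 3 to compound 4 is then a step that the limit leaves unreadable from compound 3 to compound 4, most likely reported once more as a limit rather than a number.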

Compound 4, half-maximal cytotoxic concentration: > 20000 nM
Compound 4: only a limit was reported; the forecaster's own chance of this, stated with the estimate: 80%; the middle value does not contradict the limit.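

In this assay compound 4 gives > 20000 nM, which is a limit of the assay and not a number. The steps joining compound 4 to compound 1, compound 2 and compound 3 therefore cannot be read, as all four compounds share one end point: the limit of > 20000 nM in this assay, at which 4 of the 4 values shown sit.

The compounds shown leave open whether any of them differs from the others in cytotoxicity, and by how much.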